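Series notes: O-methyl against free hydroxyl on the aryl imine

A few compounds are considered here, and "the series" means these few. Any claim that something is new, unique, unknown or untested is made for them only; others in the source may bear on it.

Measured so far in a functional assay on cells (Homo sapiens) for cytotoxicity, read by MTT assay, with a stated time of 24 h; on this read-out lower numbers stand for stronger inhibition and higher numbers for weaker inhibition:
compound 1, `CCCCCCCCCCCCCCNC(=O)[C@H](CO)/N=C/c1ccc(O)cc1`: 19300 nM
compound 2, `CCCCCCCCCCCCCCNC(=O)[C@H](CO)/N=C/c1ccccc1OC`: 12500 nM
compound 3, `CCCCCCCCCCCCCCNC(=O)[C@H](CO)NCc1ccccc1[N+](=O)[O-]`: 29400 nM

Compound 2 gives the lowest of the three numbers in this assay. Among the measured compounds shown here, its nearest neighbour is compound 1, which lies within the scatter of it; compound 3, the reduced amine with a nitro group, sits beyond the scatter from compound 2, and no single-point step links it to the other two.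

Compound 4, `CCCCCCCCCCCCCCNC(=O)[C@H](CO)/N=C/c1ccccc1O`, is the next candidate. Against compound 2 the change is hydrogen in place of methyl on an oxygen on an aromatic ring, that is methoxy to hydroxy, 2-methoxyphenyl to 2-hydroxyphenyl.

For the measured compounds named here, only one measured step bears on this. It is a 1.5-fold lower number from compound 1 to compound 2 (0.19 log units; within the scatter), and it bundles two changes at once: the move of the oxygen substituent from the 4-position to the 2-position and the swap of hydroxy for methoxy. The step was within the scatter, so neither part of it can be credited with an effect. On that basis no step beyond the scatter is expected in this assay for the swap back from methoxy to hydroxy, in either direction.

Compound 4 is therefore estimated at 15000 nM, with a range of 7000 nM to 32000 nM, corresponding to an expected step of a 1.2-fold higher number from compound 2 to compound 4 (0.08 log units; within the scatter).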

Compound 4, half-maximal inhibitory concentration: 19000 nM
Compound 4: the middle estimate sits 1.3-fold (0.10 log units) below what was measured; low and high end bracket the measured number.
By their numbers in this assay, from the lowest: compounds 2, 4, 1 and 3 (each within the scatter of the next, the first and the last beyond it).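

In this assay, the swap of methoxy for hydroxy can now be read by itself, with the oxygen on the same ring place, and it gives a 1.5-fold higher number from compound 2 to compound 4 (0.18 log units; within the scatter), so removing the methyl from this oxygen produces no step beyond the scatter. The other part of the earlier bundled step can also be read separately: with hydroxy kept, 2-hydroxyphenyl in place of 4-hydroxyphenyl gives a 1.0-fold lower number from compound 1 to compound 4 (0.01 log units; within the scatter), so this change of place also produces no step beyond the scatter, and neither part of the earlier step has an effect that can be resolved in this assay. Nothing at hand speaks to why these changes stay within the scatter.

The compounds shown leave open whether an amine or a carboxylic acid in place of the hydroxy on the aromatic ring would give a step beyond the scatter, since only oxygen substituents have been compared one place at a time on the imine. They also leave open whether a longer chain on the amide nitrogen would move the number, and how 2-hydroxyphenyl would read on the reduced amine carried by compound 3.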